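A few compounds are considered here, and "the series" means these few. Any claim that something is new, unique, unknown or untested is made for them only; others in the source may bear on it.

Measured so far in a functional assay on HeLa cells (Homo sapiens) for cytotoxicity, read by MTT assay, with a stated time of 72 h; on this read-out lower numbers stand for stronger inhibition and higher numbers for weaker inhibition:
compound 1 `COc1cccc(/C=C/C(=O)Nc2cc(C(=O)c3cc(OC)c(OC)c(OC)c3)ccc2OC)c1` gives 3100 nM
compound 2 `C#CCOc1cccc(/C=C/C(=O)Nc2cc(C(=O)c3cc(OC)c(OC)c(OC)c3)ccc2OC)c1` gives 14000 nM
compound 3 `COc1cc(/C=C/C(=O)Nc2cc(C(=O)c3cc(OC)c(OC)c(OC)c3)ccc2OC)ccc1F` gives 13600 nM

Compound 3 stands second highest of the three numbers in this assay; compound 2 sits within the scatter of it, while compound 1 lies well below, the step of a 4.4-fold higher number from compound 1 to compound 3 (0.64 log units; beyond the scatter) being beyond the scatter. The step of a 4.5-fold higher number from compound 1 to compound 2 (0.65 log units; beyond the scatter) was of the same size.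

Compound 4 `COc1ccc(C(=O)c2cc(OC)c(OC)c(OC)c2)cc1NC(=O)/C=C/c1cccc(OC(F)(F)F)c1` differs from compound 3 in one place: 3-(trifluoromethoxy)phenyl in place of 4-fluoro-3-methoxyphenyl on a double-bonded chain carbon bound to a double-bonded chain carbon. Within the data shown here, no measured step covers this exact change. The two steps that bear on it, both from compound 1, each show a modest rise when the 3-methoxyphenyl end of compound 1 is altered, whether by the added fluoro of compound 3 or by the propargyloxy of compound 2. Compound 4 keeps a single 3-substituent as in compound 1 but a larger one, as in compound 2. A number somewhere between those of compound 1 and compound 3 is therefore expected, the estimated step being a 1.7-fold lower number from compound 3 to compound 4 (0.23 log units; within the scatter).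

Compound 4 is expected to give 8000 nM in this assay, within a range of 3000 nM to 22000 nM.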

Compound 4, half-maximal inhibitory concentration: 7900 nM
For compound 4 the middle estimate is 1.0-fold (0.01 log units) above the measured one, within the range that was stated.
By their numbers in this assay, from the lowest: compound 1; then compounds 4, 3 and 2 (each within the scatter of the next).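

In this assay, trifluoromethyl in place of methyl on the oxygen of compound 1 also weakens the read-out (a 2.5-fold higher number from compound 1 to compound 4 (0.41 log units; beyond the scatter)), so all three changes shown at this end of the molecule go the same way from compound 1. Compound 4 does not separate from the other two altered compounds (a 1.7-fold lower number from compound 3 to compound 4 (0.24 log units; within the scatter); a 1.8-fold lower number from compound 2 to compound 4 (0.25 log units; within the scatter)): both steps lie within the scatter, so 3-(trifluoromethoxy)phenyl, 3-(propargyloxy)phenyl and 4-fluoro-3-methoxyphenyl cannot be told apart in this series. Nothing at hand bears on the reason for these steps.

Still open, from the compounds shown here alone, is how a hydroxyl, an amine or a longer alkoxy chain on this ring would compare with the methoxy of compound 1. Also open, going by these compounds, is whether any group at this end gives a lower number than compound 1.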